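The source may report more compounds than this note shows. Statements on the series, on what has been measured and on what is new or still open speak of the compounds shown alone.

Three related compounds have been measured in a functional assay on KB cells (Homo sapiens) for inhibition, with a stated time of 72 h; a lower number here means a stronger inhibitor, a higher number a weaker inhibitor. Compound 1, `COc1ccc(S(=O)(=O)N2CCc3cccc(-c4ccc([N+](=O)[O-])cc4)c32)cc1`, gives 52.5 nM. Compound 2, `COc1ccc(S(=O)(=O)N2CCc3cccc(-c4ccc(O)cc4)c32)cc1`, gives 129 nM, and compound 3, `COc1ccc(S(=O)(=O)N2CCc3cccc(-c4ccc(N(C)C)cc4)c32)cc1`, gives 539 nM. Compound 3 therefore has the highest number of the three: the steps of a 4.2-fold higher number from compound 2 to compound 3 (0.62 log units; beyond the scatter) and a 10-fold higher number from compound 1 to compound 3 (1.01 log units; beyond the scatter) both lie beyond the scatter, so compound 3 is the weakest inhibitor of the set.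

Compound 4, `COc1ccc(S(=O)(=O)N2CCc3cccc(-c4cccs4)c32)cc1`, has not yet been measured. It differs from compound 3 in one place: thiophen-2-yl in place of 4-(dimethylamino)phenyl on an aromatic carbon. Every measured step keeps the six-membered aromatic ring and exchanges only the group it carries; the steps of a 2.5-fold higher number from compound 1 to compound 2 (0.39 log units; beyond the scatter) and a 4.2-fold higher number from compound 2 to compound 3 (0.62 log units; beyond the scatter) were modest, while a 10-fold higher number from compound 1 to compound 3 (1.01 log units; beyond the scatter) was large. Going by the values given here, no measured step exchanges that ring itself for a thiophen-2-yl group, so there is no direct guide to the size or direction of this change. The measured steps do show that what sits at this position can move the number well beyond the scatter in either sense. A move toward a lower number seems a little more likely than a further rise, and the expected step is a 2.7-fold lower number from compound 3 to compound 4 (0.43 log units; beyond the scatter). Compound 4 is therefore estimated at 200 nM, within a range from 50 nM to 800 nM.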

Compound 4, half-maximal inhibitory concentration: 215 nM
Estimate against measurement, compound 4: 1.1-fold (0.03 log units) below; the measured number falls inside the stated range.
By their numbers in this assay, from the lowest: compound 1; then compounds 2 and 4 (each within the scatter of the next); then compound 3.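

In this assay, exchanging the 4-(dimethylamino)phenyl group for thiophen-2-yl, a five-membered aromatic ring containing sulfur, gives a 2.5-fold lower number from compound 3 to compound 4 (0.40 log units; beyond the scatter) and shows that a six-membered aromatic ring of carbon only is not needed at this position for a number of this order. Set against the 4-hydroxyphenyl group, the same exchange gives a 1.7-fold higher number from compound 2 to compound 4 (0.22 log units; within the scatter) with no order to be drawn between the two, whereas set against the 4-nitrophenyl group it gives a 4.1-fold higher number from compound 1 to compound 4 (0.61 log units; beyond the scatter) and leaves compound 1 with the lowest number of the set. No measurement shown here offers an explanation for any of these steps.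

Going by these compounds, what remains open is whether the result belongs to thiophen-2-yl in particular or would also hold for thiophen-3-yl or a furan-2-yl ring. On these data alone, it is also open whether a nitro group carried on the thiophene ring would bring the number closer to that of compound 1, and how an unsubstituted phenyl group would compare with all of these.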